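Amide aryl exchange: from compound 3 to compound 4

This account rests on a few compounds, and the source may have more. Where it says the series, first, only, none or still open, it means among the compounds named here.

Compound 3 `O=C(NCN1CCC(c2cccc[n+]2[O-])CC1)c1ccc(F)c(Cl)c1` gives 67% in a functional assay on HEK293 cells for agonist activity at D(4) dopamine receptor (Homo sapiens), read by FLIPR (on this read-out higher numbers stand for larger maximal responses and lower numbers for smaller maximal responses), level with compound 1 `Cc1cc(C(=O)NCN2CCC(c3cccc[n+]3[O-])CC2)ccc1F`, which gives 67%, and both stand at the top of the three numbers; compound 2 `O=C(NCN1CCC(c2cccc[n+]2[O-])CC1)c1ccccc1` gives 63%. All three steps lie within the scatter: no change at the digits printed from compound 1 to compound 3 (within the scatter), a number 4 percentage points lower from compound 1 to compound 2 (within the scatter) and a number 4 percentage points higher from compound 2 to compound 3 (within the scatter).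

Compound 4 `Cc1cccc(C(=O)NCN2CCC(c3cccc[n+]3[O-])CC2)c1` differs from compound 3 in the aryl group on the carbonyl carbon: 3-methylphenyl in place of 3-chloro-4-fluorophenyl on a carbonyl carbon. Among the compounds with values here, the steps that bear on this are the two aryl exchanges on the carbonyl carbon, a number 4 percentage points higher from compound 2 to compound 3 (within the scatter) and a number 4 percentage points lower from compound 1 to compound 2 (within the scatter), neither beyond the scatter. On this basis no step beyond the scatter is expected in this assay, with a number 2 percentage points lower from compound 3 to compound 4 (within the scatter) the estimated change. Compound 4 is expected to give 65%, within 55% to 75%.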

Compound 4, largest response reached (reported as efficacy), in percent of the reference or control that the assay uses: 77%
For compound 4 the middle estimate is 12 percentage points below the measured one; measured number above the stated range.
By their numbers in this assay, from the lowest: compounds 2, 1, 3 and 4 (each within the scatter of the next, the first and the last beyond it).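

In this assay, the aryl group on the carbonyl carbon now gives one step beyond the scatter: with methyl in place of hydrogen on an aromatic carbon, there is a number 14 percentage points higher from compound 2 to compound 4 (beyond the scatter). The 3-methylphenyl group is not separated from the other two substituted aryl groups, with a number 10 percentage points higher from compound 3 to compound 4 (within the scatter) and a number 10 percentage points higher from compound 1 to compound 4 (within the scatter). No available evidence accounts for the step beyond the scatter.

Open, going by these compounds, is how a methoxy group, a nitrile or a carboxylic acid on this aryl ring would read in this assay.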